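Methyl Replaces Methoxycarbonyl Beside Two Limits

The compounds below may be only part of what the source reports. "The series", "measured", "known", "first", "only" and "open" are said of these compounds alone.

Compound 1 `N#Cc1ccc(Cn2cc(/C=C3\NC(=O)NC3=O)c3ccccc32)cc1`: > 40000 nM
Compound 2 `COC(=O)c1ccc(Cn2cc(/C=C3\NC(=O)NC3=O)c3ccccc32)cc1`: > 40000 nM

In a functional assay on A549 cells (Homo sapiens) for antiproliferative activity, read by trypan blue exclusion, with a stated time of 24 h (a higher number here means a weaker inhibitor, a lower number a stronger inhibitor), compound 1 reaches only a limit, > 40000 nM. Compound 2 likewise shows only a limit, > 40000 nM. The step that the two limits leave unreadable from compound 1 to compound 2 cannot be read, as both values sit at the limit of > 40000 nM in this assay, at which 2 of the 2 values shown sit. Compound 2 therefore stands at the limit, with no number to place it. Compound 3 `Cc1ccc(Cn2cc(/C=C3\NC(=O)NC3=O)c3ccccc32)cc1` differs from it by methyl in place of methoxycarbonyl on an aromatic carbon. The single step shown is unreadable, so no measured step gives a size for this change. The expected step is a number no higher from compound 2 to compound 3 (the limit leaves the size open), no shift beyond the scatter. Compound 3 is expected to give 40000 nM, between 10000 nM and 120000 nM.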

Compound 3, half-maximal inhibitory concentration: 34800 nM
The estimate for compound 3 lay 1.1-fold (0.06 log units) above the measured number, and the stated range covers the measured number.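

In this assay, within the data shown here, methyl is the first group at this place, on an aromatic carbon para to a large group, to give a number rather than a limit. Set against methoxycarbonyl the result is an at least 1.1-fold lower number from compound 2 to compound 3 (0.06 log units; that floor lies within the scatter), and set against the nitrile it is an at least 1.1-fold lower number from compound 1 to compound 3 (0.06 log units; that floor lies within the scatter). Each of these is only a floor, and the step between compound 1 and compound 2 cannot be read: the limit of > 40000 nM in this assay, at which 2 of the 3 values shown sit.

The compounds shown leave open whether an amine, a carboxylic acid or a longer chain at this place would give a number, and how far that number would lie from compound 3.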